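The source may report more compounds than this note shows. Statements on the series, on what has been measured and on what is new or still open speak of the compounds shown alone.

Compound 1 `Cc1ccc(Cn2c(=O)n(C[C@H](C)C(=O)O)c(=O)[nH]/c2=N\c2ccc(OC(C)C)c(Cl)c2)cc1` and compound 2 `C[C@@H](Cn1c(=O)[nH]/c(=N\c2ccc(Oc3nccs3)cc2)n(Cc2ccc(Cl)cc2)c1=O)C(=O)O` share one core and differ in several places at once. In an ADME assay on the whole organism (plasma, Rattus norvegicus) for protein binding, using cassette dosing, at a dose of 1 mg/kg (on this read-out higher numbers stand for a larger free fraction and lower numbers for a smaller free fraction), compound 1 gives 0.014, while compound 2 gives 0.006, the lower of the two numbers and beyond the usual scatter from compound 1. Compound 3 `C[C@@H](Cn1c(=O)[nH]/c(=N\c2ccc(OC3CCC3)cc2)n(Cc2ccc(Cl)cc2)c1=O)C(=O)O` is built from compound 2 by one change: cyclobutyl in place of 1,3-thiazol-2-yl on an oxygen on an aromatic ring. Within the data shown here, no measured pair shows this change on its own, so its effect can only be estimated. A small rise in free fraction, within the scatter, is expected a 1.3-fold higher number from compound 2 to compound 3 (0.12 log units; within the scatter). Compound 3 is estimated at 0.008, in the range 0.004 to 0.016.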

Compound 3, unbound fraction: 0.015
The estimate for compound 3 lay 1.9-fold (0.27 log units) below the measured number, within the range that was stated.
By their numbers in this assay, from the lowest: compound 2; then compounds 1 and 3 (each within the scatter of the next).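

On the oxygen on the aromatic ring, cyclobutyl in place of 1,3-thiazol-2-yl gives a 2.5-fold higher number from compound 2 to compound 3 (0.40 log units; beyond the scatter) in this assay. Among these compounds, this is the first comparison that isolates one place, and it shows that this group alone can shift the free fraction by a modest but real amount. No measurement shown here accounts for the rise. Going by these compounds, whether an open chain such as n-butyl, or an amine, on the same oxygen would shift it further remains open. So does whether the step holds with other groups elsewhere on the shared core.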